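Fluorophenyl to Cyanophenyl on the Sulfonyl Sulfur

The compounds below may be only part of what the source reports. "The series", "measured", "known", "first", "only" and "open" are said of these compounds alone.

Compound 1 `CC1CCN(c2c(S(=O)(=O)c3ccccc3)cnc3ccccc23)CC1`: 89.2%
Compound 2 `COCC1CCN(c2c(S(=O)(=O)c3ccc(F)cc3)cnc3cc(F)ccc23)CC1`: 76.1%

Of the compounds shown here, two sharing one core have been measured in an assay on isolated protein for displacement of a labelled ligand from metabotropic glutamate receptor 5 (Homo sapiens), with a stated time of 60 min, tested at 1 uM; a lower number here means less inhibition, a higher number more inhibition at the concentration tested (going by the name of the read-out). Compound 1 gives 89.2% in this assay. Compound 2 gives 76.1% in this assay, the lower of the two numbers, and its gap to compound 1 lies beyond the usual scatter. The two compounds differ in several places at once, so no single structural change can be tied to that gap.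

Compound 3 `COCC1CCN(c2c(S(=O)(=O)c3cccc(C#N)c3)cnc3cc(F)ccc23)CC1` differs from compound 2 in one place: 3-cyanophenyl in place of 4-fluorophenyl on a sulfonyl sulfur. Among the compounds with values here, no pair of measured compounds differs in that place, so the two numbers give no direct guide to the size of this step. Because compound 2 sits at 76.1%, a step of a number 4.1 percentage points lower from compound 2 to compound 3 (within the scatter) in this assay is expected, within the usual scatter, in no firm direction. Compound 3 is therefore estimated at 72%, with a range from 55% to 88%.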

Compound 3, a percentage reported as inhibition, at one concentration (the size of the read-out at that concentration, not a potency): 91%
Estimate against measurement, compound 3: 19 percentage points below; the measured number lies above the stated range.
By their numbers in this assay, from the lowest: compound 2; then compounds 1 and 3 (each within the scatter of the next).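

In this assay, within the data shown here, the step of 3-cyanophenyl in place of 4-fluorophenyl on a sulfonyl sulfur, a number 14.9 percentage points higher from compound 2 to compound 3 (beyond the scatter), is the first change in this set that can be tied to a single place. It shows that the aryl group on the sulfonyl sulfur can move this read-out by more than the scatter while the rest of compound 2 stays fixed, which the first two compounds, differing in several places at once, could not show. Nothing measured here accounts for the direction or size of this step.

The compounds shown leave open whether the nitrile itself or its place on the ring carries the step. They also leave open how an amide or a methoxy group on that phenyl ring would compare with the nitrile.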